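Swapping thiophen-3-yl for 1H-indol-3-yl on the carbonyl carbon

The compounds below may be only part of what the source reports. "The series", "measured", "known", "first", "only" and "open" are said of these compounds alone.

In a functional assay on MCF7 cells (Homo sapiens) for antiproliferative activity, read by XTT assay, with a stated time of 72 h (on this read-out lower numbers stand for stronger inhibition and higher numbers for weaker inhibition), the two measured compounds stand as follows:

compound 1 `COc1ccc(-c2cc3ccccc3nc2/C=C/C(=O)c2ccc(OC)c(OC)c2)cc1`: 6030 nM
compound 2 `COc1ccc(-c2cc3ccccc3nc2/C=C/C(=O)c2ccsc2)cc1`: 6010 nM

Among the compounds with values here, compound 2 holds the lowest of the two numbers, yet its nearest neighbour is compound 1, and the only measured step, a 1.0-fold lower number from compound 1 to compound 2 (0.00 log units; within the scatter), lies within the scatter. Thiophen-3-yl in place of 3,4-dimethoxyphenyl on the carbonyl carbon therefore left the read-out unchanged.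

Compound 3 `COc1ccc(-c2cc3ccccc3nc2/C=C/C(=O)c2c[nH]c3ccccc23)cc1` carries the next change at the same place: 1H-indol-3-yl in place of thiophen-3-yl on a carbonyl carbon. Within the data shown here, no measured step involves 1H-indol-3-yl, so the only guide is the step from compound 1 to compound 2, which showed that exchanging one aryl group for another on this carbonyl carbon made no difference beyond the scatter. As far as these compounds go, because a 1.0-fold lower number from compound 1 to compound 2 (0.00 log units; within the scatter) was flat, the expectation for compound 3 is a step of a 1.0-fold lower number from compound 2 to compound 3 (0.00 log units; within the scatter), that is, none beyond the scatter, though the wider range reflects that indole is untested here. Compound 3 is thus estimated at 6000 nM, within 2000 nM to 18000 nM.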

Compound 3, half-maximal inhibitory concentration: > 10000 nM
Compound 3: a limit, no number; the forecaster's own chance of this, stated with the estimate: 5%; middle value at least 1.6-fold (0.22 log units) away from the limit.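

In this assay compound 3 gives > 10000 nM, which is a limit of the assay and not a number. Read against that limit, the change shows an at least 1.6-fold higher number from compound 2 to compound 3 (0.22 log units; that floor lies within the scatter) and an at least 1.6-fold higher number from compound 1 to compound 3 (0.21 log units; that floor lies within the scatter), so both steps are floors: the true size of each may lie within the scatter or beyond it. What this adds to the flat exchange of 3,4-dimethoxyphenyl for thiophen-3-yl is that a group on this carbonyl carbon, here 1H-indol-3-yl, can carry the read-out to the end of the measured range, and the comparison stops there: the limit of > 10000 nM in this assay, at which 1 of the 3 values shown sits.

The compounds shown leave open whether 1H-indol-3-yl truly weakens the read-out at this position or stays level with the other two groups. They also leave open what a methyl group on the indole nitrogen, as in 1-methyl-1H-indol-3-yl, or an amine such as piperidin-4-yl would give on the same carbonyl carbon.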